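The source may hold more compounds than are shown below. What is called first, only, known or untested is meant among the compounds shown, and "the series" means these compounds.

In a functional assay on MV4-11 cells (Homo sapiens) for inhibition, read by resazurin assay, with a stated time of 72 h; on this read-out higher numbers stand for weaker inhibition of growth and lower numbers for stronger inhibition of growth:
- compound 1 `Cc1ccc(-c2cncc(Cl)c2N2CCC3(CCNC3=O)CC2)o1`: 4950 nM
- compound 2 `CC(=O)c1ccc(-c2cncc(Cl)c2N2CCC3(CCNC3=O)CC2)s1`: 1440 nM
- compound 3 `O=Cc1ccc(-c2cncc(Cl)c2N2CCC3(CCNC3=O)CC2)s1`: 750 nM

The numbers show a 6.6-fold lower number from compound 1 to compound 3 (0.82 log units; beyond the scatter), while a 1.9-fold lower number from compound 2 to compound 3 (0.28 log units; within the scatter). Compound 3 therefore shares the low end of this small set with compound 2.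

Compound 4 `Cn1cccc1-c1cncc(Cl)c1N1CCC2(CCNC2=O)CC1` has 1-methyl-1H-pyrrol-2-yl in place of 5-formylthiophen-2-yl on an aromatic carbon.

Within the data shown here, no measured step makes this exact swap. The closest guide is compound 1, which also lacks a carbonyl on its five-membered aromatic ring, and the data show a 6.6-fold lower number from compound 1 to compound 3 (0.82 log units; beyond the scatter) and a 3.4-fold lower number from compound 1 to compound 2 (0.54 log units; beyond the scatter). A modest rise in this assay is therefore expected, though a pyrrole has not yet been tested here. The expected change is a 4.0-fold higher number from compound 3 to compound 4 (0.60 log units; beyond the scatter). For compound 4 the estimated value is 3000 nM, within an expected range of 800 nM to 10000 nM.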

Compound 4, concentration for 50% growth inhibition: 900 nM
The estimate for compound 4 lay 3.3-fold (0.52 log units) above the measured number; measured number inside the range.
By their numbers in this assay, from the lowest: compounds 3, 4 and 2 (each within the scatter of the next); then compound 1.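

In this assay the 1-methyl-1H-pyrrol-2-yl group has no carbonyl, yet the data show a 1.2-fold higher number from compound 3 to compound 4 (0.08 log units; within the scatter) and a 1.6-fold lower number from compound 2 to compound 4 (0.20 log units; within the scatter) and so a carbonyl on this five-membered ring is not required at this position. The same group gives a 5.5-fold lower number from compound 1 to compound 4 (0.74 log units; beyond the scatter) even though neither compound carries a carbonyl on this ring, so lacking one does not by itself go with the highest number. Nothing measured here explains these results.

Still open, from the compounds shown here alone, is how an amine or a carboxylic acid on this ring would behave. A phenyl ring in this place is equally untested by the compounds shown.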